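Swapping methyl for fluoro on a saturated ring carbon

A few compounds are considered here, and "the series" means these few. Any claim that something is new, unique, unknown or untested is made for them only; others in the source may bear on it.

Of the compounds shown here, three sharing one core have been measured so far. In a physicochemical assay for lipophilicity, at pH 7.4 (a higher number here means a more lipophilic compound, a lower number a more polar compound), compound 1 `CC1(CS(C)(=O)=O)CN(c2cc(COc3ccc(F)c(F)c3F)nc(-c3ccccn3)n2)C1` gives 2.9 and compound 2 `CC1(C#N)CN(c2cc(COc3ccc(F)c(F)c3F)nc(-c3ccccn3)n2)C1` gives 3.3 while compound 3 `CC1(COc2cc(COc3ccc(F)c(F)c3F)nc(-c3ccccn3)n2)COC1` stands highest of the three at 4 on this scale.

Compound 4 `Fc1ccc(OCc2cc(OCC3(F)COC3)nc(-c3ccccn3)n2)c(F)c1F` has not yet been measured. Its difference from compound 3 is fluoro in place of methyl on a saturated ring carbon and in words it is fluoro in place of methyl on a saturated ring carbon, which turns (3-methyloxetan-3-yl)methoxy into (3-fluorooxetan-3-yl)methoxy.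

Within the data shown here, no measured pair makes this exchange, so the evidence is indirect. The step closest in kind is a number 0.40 log units higher from compound 1 to compound 2 (beyond the scatter) for cyano in place of (methylsulfonyl)methyl on a saturated ring carbon. The steps of a number 0.70 log units higher from compound 2 to compound 3 (beyond the scatter) and a number 1.10 log units higher from compound 1 to compound 3 (beyond the scatter) replace the whole group on an aromatic carbon and say less about so limited a change. The smallest of the three is a number 0.40 log units higher from compound 1 to compound 2 (beyond the scatter) and the present change is expected to move the number by less than that. The data give no direction for it, and a slight fall is the likelier guess. The estimated step is a number 0.30 log units lower from compound 3 to compound 4 (within the scatter) and it is expected to be small. In this assay compound 4 is estimated at 3.7 with 3.3 to 4.1 as the expected range.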

Compound 4, distribution coefficient: 4
Compound 4: the middle estimate sits 0.30 log units below what was measured, and the stated range covers the measured number.
By their numbers in this assay, from the lowest: compound 1; then compound 2; then compounds 3 and 4 (each within the scatter of the next).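

In this assay, among these compounds, the first direct reading of fluoro in place of methyl on a saturated ring carbon, two ring bonds from the ring oxygen of the four-membered ring, is no change at the digits printed from compound 3 to compound 4 (within the scatter), so at this position the exchange leaves the number where compound 3 had it. The two steps that replace the whole group on an aromatic carbon read a number 0.70 log units higher from compound 2 to compound 4 (beyond the scatter) and a number 1.10 log units higher from compound 1 to compound 4 (beyond the scatter), so the fluoro-bearing group stands as far from both azetidine compounds as the methyl-bearing group does. The data shown offer no measured explanation for why the exchange leaves the number as it is.

From the compounds shown here alone, all of this rests on a single pair, so it remains open whether the same exchange would read alike on the methyl-bearing carbon of either azetidine compound. Going by these compounds, it also remains open how a hydroxyl, an amine or a longer chain on the oxetane carbon would read in this assay.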